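Working notes: estimate for compound 4 from compounds 1 to 3

The source may hold more compounds than are shown below. What is called first, only, known or untested is meant among the compounds shown, and "the series" means these compounds.

Measured in an in vitro functional assay on HEK285-7 cells for antagonist activity at prostaglandin D2 receptor 2 (Homo sapiens), read by BRET and beta-arrestin recruitment; a higher number here means a larger maximal response, a lower number a smaller maximal response:
- compound 1 `O=C(O)Cc1sc(C(c2ccccc2)c2ccccc2)nc1-c1ccccc1` gives 80%
- compound 2 `O=C(O)Cc1sc(C(c2ccc(F)cc2)c2ccc(F)cc2)nc1-c1ccccc1` gives 80%
- compound 3 `O=C(O)Cc1sc(C2COc3ccccc3O2)nc1-c1ccc(Cl)cc1` gives 50%

Compound 2 sits level with compound 1 at the digits shown, the two together the highest of the three numbers; compound 3 lies lower than compound 2, beyond the scatter. Compound 4 `O=C(O)Cc1sc(C(c2ccc(F)cc2)c2ccc(F)cc2)nc1-c1ccnc(O)c1` is not yet measured. Against compound 2 its change is 2-hydroxypyridin-4-yl in place of phenyl on an aromatic carbon. Within the data shown here, no measured pair differs in this one place, so no measured step sets the size. Compound 3 carries another group on that aromatic carbon and gives the lowest number, but it differs from compound 2 elsewhere too, so its gap is only a loose hint of downward room. The step of a number 10 percentage points lower from compound 2 to compound 4 (within the scatter) is expected to be small, a modest loss or none beyond the scatter. For compound 4 the value expected in this assay is 70%, within 50% to 90%.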

Compound 4, largest response reached (reported as efficacy), in percent of the reference or control that the assay uses: 60%
Compound 4: the middle estimate sits 10 percentage points above what was measured; measured number inside the range.
By their numbers in this assay, from the lowest: compounds 3 and 4 (each within the scatter of the next); then compounds 1 and 2 (each within the scatter of the next).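

In this assay, among these compounds, 2-hydroxypyridin-4-yl in place of phenyl on the aromatic carbon next to the ring nitrogen gives a number 20 percentage points lower from compound 2 to compound 4 (beyond the scatter) as the first reading of a change at this position alone. This position is therefore not silent: with the rest of compound 2 held fixed, replacing the phenyl moves the maximal response beyond the scatter. No available evidence bears on the reason for this step.

The compounds shown leave open whether the ring nitrogen or the hydroxy group carries the step. Pyridin-4-yl or 3-hydroxyphenyl on this carbon would separate the two.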